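Indole Diketopiperazine Series: Removing the Prenyl Chain

A few compounds are considered here, and "the series" means these few. Any claim that something is new, unique, unknown or untested is made for them only; others in the source may bear on it.

Measured so far:
- Compound 1 `C=CC(C)(C)c1[nH]c2ccc(C[C@@H](O)C(C)(C)Cl)cc2c1/C=C1\NC(=O)[C@H](C)NC1=O` — 79000 nM
- Compound 2 `C=CC(C)(C)c1[nH]c2c(CC=C(C)C)cccc2c1/C=C1\NC(=O)[C@H](C)NC1=O` — 86000 nM

In a functional assay (on this read-out higher numbers stand for weaker inhibition and lower numbers for stronger inhibition), compound 1 gives 79000 nM. In this assay compound 2 gives 86000 nM; this is the higher of the two numbers, yet its gap to compound 1 lies within the scatter, so the two read as equal.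

Compound 3 `C=CC(C)(C)c1[nH]c2ccccc2c1/C=C1\NC(=O)[C@H](C)NC1=O` has not been measured. It differs from compound 2 in one place: hydrogen in place of 3-methylbut-2-en-1-yl on an aromatic carbon. Among the compounds with values here, no measured pair shows this change, so the step from compound 2 to compound 3 is expected to be small, with no clear direction beyond the scatter, as a 1.0-fold higher number from compound 2 to compound 3 (0.02 log units; within the scatter). For compound 3 the estimate in this assay is 90000 nM, with a range from 40000 nM to 200000 nM.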

Compound 3, half-maximal inhibitory concentration: 103000 nM
Estimate against measurement, compound 3: 1.1-fold (0.06 log units) below, and the stated range covers the measured number.
By their numbers in this assay, from the lowest: compounds 1, 2 and 3 (each within the scatter of the next).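

In this assay, hydrogen in place of 3-methylbut-2-en-1-yl gives no change beyond the scatter (a 1.2-fold higher number from compound 2 to compound 3 (0.08 log units; within the scatter)), and hydrogen in place of 3-chloro-2-hydroxy-3-methylbutyl likewise (a 1.3-fold higher number from compound 1 to compound 3 (0.12 log units; within the scatter)). Neither chain therefore separates from plain hydrogen on this read-out, and compounds 1, 2 and 3 read as equal. Nothing measured on these compounds bears on why this is so.

As far as these compounds go, whether an amine or a carboxylic acid on the same aromatic carbon would move the number stays open. So does whether any group there can bring the number clearly below that of compound 3.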